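Chloro for hydrogen, repeated on a second core

The source may hold more compounds than are shown below. What is called first, only, known or untested is meant among the compounds shown, and "the series" means these compounds.

Compound 1 `CC(C)C(c1ccccc1)c1nc2c(C(F)(F)F)cccc2c(C(=O)O)c1O` and compound 2 `CC(C)C(c1ccc(Cl)cc1)c1nc2c(C(F)(F)F)cccc2c(C(=O)O)c1O` differ in one place: chloro in place of hydrogen on an aromatic carbon. In an assay on isolated protein for inhibition of P-selectin glycoprotein ligand 1 (Homo sapiens), read by surface plasmon resonance, tested at 250 uM (a lower number here means less inhibition, a higher number more inhibition at the concentration tested (going by the name of the read-out)), compound 1 gives 58%. Compound 2 sits at a limit of this assay, <= 10%, which is the limit of <= 10% in this assay, at which 1 of the 3 values shown sits. That change gave a number at least 48 percentage points lower from compound 1 to compound 2 (beyond the scatter).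

Compound 3 `Cc1cc(C(F)(F)F)c2nc(C3(c4ccccc4)CC3)c(O)c(C(=O)O)c2c1` and compound 4 `Cc1cc(C(F)(F)F)c2nc(C3(c4ccc(Cl)cc4)CC3)c(O)c(C(=O)O)c2c1` are separated by the same change, (chloro in place of hydrogen on an aromatic carbon), with the place described in the same words. How the core of compound 3 differs from the core of compound 1 is not broken down here. In this assay compound 3 gives 40%, a value below that of compound 1 and beyond the scatter.

Compound 4 is expected to show a number 32 percentage points lower from compound 3 to compound 4 (beyond the scatter) because the same change gave a number at least 48 percentage points lower from compound 1 to compound 2 (beyond the scatter). For compound 4 the estimated value is 8%, between 0% and 25%.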

Compound 4, a percentage reported as inhibition, at one concentration (the size of the read-out at that concentration, not a potency): 65%
For compound 4 the middle estimate is 57 percentage points below the measured one; the measured number lies above the stated range.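

Phenyl to 4-chlorophenyl on the core of compound 3 gave a number 25 percentage points higher from compound 3 to compound 4 (beyond the scatter). Set beside the same change on the core of compound 1, the result in this assay did not carry over from one core to the other: the same change on two cores in this assay, a number at least 48 percentage points lower (beyond the scatter) from compound 1 to compound 2 and a number 25 percentage points higher (beyond the scatter) from compound 3 to compound 4, at least 73 percentage points apart, beyond the scatter of two such steps. These two pairs show that the same change can go opposite ways in this series, but they do not show why, nor how it would behave on any further core.

The compounds shown leave open whether fluoro, methoxy or a carboxylic acid in place of the chloro would also separate the two cores. They also leave open which of the differences between the two cores goes with the opposite steps.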